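The source may hold more compounds than are shown below. What is called first, only, known or untested is meant among the compounds shown, and "the series" means these compounds.

Compound 3 `COc1ncnc2c1c(-c1cccs1)cn2[C@@H]1O[C@H](CO)[C@@H](O)[C@H]1O` gives 70 nM in a functional assay on K562 cells (Homo sapiens), read by MTT assay, with a stated time of 72 h (on this read-out higher numbers stand for weaker inhibition and lower numbers for stronger inhibition), the lowest of the two numbers recorded, while compound 1 `COc1ncnc2c1c(-c1ccsc1)cn2[C@@H]1O[C@H](CO)[C@@H](O)[C@H]1O` gives 90 nM in this assay, a value within the scatter of that of compound 3. For the measured compounds named here, the only measured step between them, a 1.3-fold lower number from compound 1 to compound 3 (0.11 log units; within the scatter), is therefore too small to be called a real change. Compound 2 `COc1nc(N)nc2c1c(-c1ccccc1)cn2[C@@H]1O[C@H](CO)[C@@H](O)[C@H]1O` carries a phenyl ring and an additional amino group on the shared core; in this assay compound 2 gives > 20000 nM, which is a limit of the assay and not a number. That entry is recorded as the limit of > 20000 nM in this assay, at which 1 of the 3 values shown sits.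

Compound 4 `COc1ncnc2c1c(-c1ccccc1)cn2[C@@H]1O[C@H](CO)[C@@H](O)[C@H]1O` is the next compound to be measured, and the change from compound 3 is phenyl in place of thiophen-2-yl on an aromatic carbon. Going by the values given here, no measured step tests this exact exchange. Among the compounds with values here, the one step available, from thiophen-3-yl to thiophen-2-yl, stayed within the scatter, so this carbon accepts at least a shift within a small aromatic ring without a change in the read-out. A six-membered ring of carbon only is a somewhat larger departure, and a modest loss is the more cautious expectation. Compound 4 is therefore expected to give about 150 nM in this assay, plausibly between 50 nM and 500 nM. The expected step of a 2.1-fold higher number from compound 3 to compound 4 (0.33 log units; beyond the scatter) lies near the edge of the scatter.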

Compound 4, half-maximal inhibitory concentration: > 20000 nM
Compound 4 was reported as a limit; the forecaster's own chance of this, stated with the estimate: 5%; middle value at least 130-fold (2.12 log units) from the limit.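

The two thiophene rings could be exchanged on this aromatic carbon without a real change, but phenyl there is a different matter in this assay. Placing phenyl on the carbon gives an at least 280-fold higher number from compound 3 to compound 4 (2.45 log units; beyond the scatter), and the same exchange starting from the other thiophene gives an at least 220-fold higher number from compound 1 to compound 4 (2.34 log units; beyond the scatter), so inhibition weakens sharply in both comparisons and this position proves far more selective about its ring than the thiophene pair could reveal. Compound 2 and compound 4, the two phenyl compounds shown, both stand at a limit of the assay and not at a number, so the step between them, which differs by the amino group, cannot be read: the limit of > 20000 nM in this assay, at which 2 of the 4 values shown sit.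

Still open, from the compounds shown here alone, is whether the loss follows the larger six-membered ring or the absence of sulfur, a question that a furan-2-yl ring, five-membered and without sulfur, or a pyridine ring, six-membered with a nitrogen, could help to separate. Also open, going by these compounds, is what an amino group on the shared core does when a thiophene ring occupies this carbon.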